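This account rests on a few compounds, and the source may have more. Where it says the series, first, only, none or still open, it means among the compounds named here.

In a functional assay on HCT-8 cells (Homo sapiens) for cytotoxicity (on this read-out higher numbers stand for an effect only at larger amounts of compound and lower numbers for an effect already at smaller amounts), compound 2 (`COC1=C(C)C(=O)/C(=C(O)/C=C/c2cc(C)cc(C)c2)C(=O)C1(C)C`) gives 2.9 ug/mL and compound 1 (`COC1=C(C)C(=O)/C(=C(O)/C=C/c2ccccc2OC)C(=O)C1(C)C`) gives 4.1 ug/mL, so the two stand together within the scatter. Compound 3 (`COC1=C(C)C(=O)/C(=C(O)/C=C/c2nccs2)C(=O)C1(C)C`) has not yet been measured. It carries 1,3-thiazol-2-yl in place of 3,5-dimethylphenyl on a double-bonded chain carbon bound to a double-bonded chain carbon. Going by the values given here, the only measured step, a 1.4-fold lower number from compound 1 to compound 2 (0.15 log units; within the scatter), exchanged one substituted phenyl group for another, and no measured step introduces a 1,3-thiazol-2-yl group. The evidence is thin, but nothing beyond the scatter is expected, and the estimated step is a 1.2-fold higher number from compound 2 to compound 3 (0.08 log units; within the scatter). For compound 3 the expected value is 3.5 ug/mL, with an estimated range of 1.3 ug/mL to 9 ug/mL.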

Compound 3, concentration for half-maximal effect: 5.1 ug/mL
For compound 3 the middle estimate is 1.5-fold (0.16 log units) below the measured one; the measured number falls inside the stated range.
By their numbers in this assay, from the lowest: compounds 2, 1 and 3 (each within the scatter of the next).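

In this assay, the place on a double-bonded chain carbon bound to a double-bonded chain carbon now holds a five-membered aromatic ring with 2 hetero atoms, not only a substituted phenyl group, and the exchange gives a 1.8-fold higher number from compound 2 to compound 3 (0.25 log units; within the scatter) and a 1.2-fold higher number from compound 1 to compound 3 (0.09 log units; within the scatter). Across these three compounds, then, neither the change of ring size nor the entry of nitrogen and sulfur moves the number beyond the scatter. No supporting data bear on why this is so. Going by these compounds, whether an amine, a carboxylic acid or a longer chain at this place would give a step beyond the scatter remains open.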